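Aryl exchange on the shared core: compound 2 to compound 3

The source may hold more compounds than are shown below. What is called first, only, known or untested is meant among the compounds shown, and "the series" means these compounds.

In a functional assay on MV4-11 cells (Homo sapiens) for antiproliferative activity, read by CCK-8 assay, with a stated time of 72 h (on this read-out lower numbers stand for stronger inhibition and higher numbers for weaker inhibition), compound 1 (`COc1ccc(C(C)(C)O)cc1-c1cn(C)c(=O)c2[nH]c(C(=O)NCc3ccc(C(=O)Nc4ccccc4N)cc3)cc12`) gives 420 nM and compound 2 (`Cc1ccccc1-c1cn(C)c(=O)c2[nH]c(C(=O)NCc3ccc(C(=O)Nc4ccccc4N)cc3)cc12`) gives 310 nM. Compound 2 therefore stands within the scatter of compound 1, and the pair cannot be ranked.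

Compound 3 (`COc1ccc(-c2cn(C)c(=O)c3[nH]c(C(=O)NCc4ccc(C(=O)Nc5ccccc5N)cc4)cc23)cc1`) has not yet been measured. The change is 4-methoxyphenyl in place of 2-methylphenyl on an aromatic carbon of a six-membered aromatic ring with 1 nitrogen.

Among the measured compounds shown here, only one measured step bears on this, and it alters the same carbon: a 1.4-fold lower number from compound 1 to compound 2 (0.13 log units; within the scatter), with 2-methylphenyl in place of 5-(1-hydroxy-1-methylethyl)-2-methoxyphenyl. That exchange of aryl groups stays within the scatter. For the measured compounds named here, no measured compound carries the 4-methoxyphenyl group, so the evidence is thin and gives no direction. No step beyond the scatter is expected in this assay, though a single step cannot exclude one.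

The expected size of the change is a 1.0-fold lower number from compound 2 to compound 3 (0.01 log units; within the scatter).

Compound 3 is estimated at 300 nM, with an expected range of 120 nM to 750 nM.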

Compound 3, half-maximal inhibitory concentration: 320 nM
Compound 3: middle estimate off by 1.1-fold (0.03 log units), on the low side; measured number inside the range.
By their numbers in this assay, from the lowest: compounds 2, 3 and 1 (each within the scatter of the next).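

In this assay, replacing 2-methylphenyl with 4-methoxyphenyl on this aromatic carbon gives a 1.0-fold higher number from compound 2 to compound 3 (0.01 log units; within the scatter), and replacing 5-(1-hydroxy-1-methylethyl)-2-methoxyphenyl with 4-methoxyphenyl gives a 1.3-fold lower number from compound 1 to compound 3 (0.12 log units; within the scatter). All three aryl groups now lie within the scatter of one another at this position, and this holds for a 4-methoxyphenyl group, which carries a hydrogen-bond acceptor where 2-methylphenyl carries none, so the earlier single step between compound 1 and compound 2 is no longer the only sign of a flat read-out here. No independent measurement accompanies these values to account for that flatness.

All three groups at this position are substituted phenyl rings, which leaves open how an amine, a carboxylic acid or a longer alkyl chain on the same carbon would read in this assay. Everything outside this aryl group is common to compound 1, compound 2 and compound 3, so these values also leave open how far the read-out depends on the remainder of the structure, including the aminophenyl amide end.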